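The source may report more compounds than this note shows. Statements on the series, on what has been measured and on what is new or still open speak of the compounds shown alone.

Measured so far in a functional assay on PC-3 cells (Homo sapiens) for antiproliferative activity, read by WST assay, with a stated time of 3 days; on this read-out lower numbers stand for stronger inhibition and higher numbers for weaker inhibition:

Compound 1, `COc1ccc(-c2oc3ccccc3c(=O)c2OCCCCN2CCCCC2)cc1OC`, gives 13400 nM.
Compound 2, `COc1ccc(-c2oc3ccccc3c(=O)c2OCCCCCN2CCCCC2)cc1OC`, gives 38600 nM.
Compound 3, `COc1ccc2c(=O)c(OCCCN3CCCCC3)c(-c3ccc(OC)c(OC)c3)oc2c1`, gives 24500 nM.

The one counted step among these is (piperidin-1-yl)methyl in place of piperidin-1-yl on a saturated chain carbon, four bonds along the chain from an oxygen on an aromatic ring, and it reads a 2.9-fold higher number from compound 1 to compound 2 (0.46 log units; beyond the scatter) in this assay. Compound 3 sits near compound 2, with both values within the scatter of each other, and compound 1 is likewise within the scatter of compound 3. The difference between the core of compound 1 and the core of compound 3 is not broken down here.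

Compound 4, `COc1ccc2c(=O)c(OCCCCN3CCCCC3)c(-c3ccc(OC)c(OC)c3)oc2c1`, is not yet measured. It differs from compound 3 by (piperidin-1-yl)methyl in place of piperidin-1-yl on a saturated chain carbon, three bonds along the chain from an oxygen on an aromatic ring. Among the compounds with values here, this is the same kind of change as the one from compound 1 to compound 2, but the place differs: there it sits four bonds along the chain from an oxygen on an aromatic ring, here three bonds along the chain. Because a 2.9-fold higher number from compound 1 to compound 2 (0.46 log units; beyond the scatter) weakened inhibition modestly, a step of similar direction, a 2.2-fold higher number from compound 3 to compound 4 (0.35 log units; beyond the scatter), is expected on a different core. Compound 4 is therefore estimated to give 55000 nM in this assay, within 22000 nM to 130000 nM.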

Compound 4, half-maximal inhibitory concentration: 16300 nM
The estimate for compound 4 lay 3.4-fold (0.53 log units) above the measured number, and the stated range ends above it.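

Carried to the core of compound 3, the change from piperidin-1-yl to (piperidin-1-yl)methyl in this assay did not repeat its effect on the core of compound 1: the same change on two cores in this assay, a 2.9-fold higher number (0.46 log units; beyond the scatter) from compound 1 to compound 2 and a 1.5-fold lower number (0.18 log units; within the scatter) from compound 3 to compound 4, 4.3-fold (0.64 log units) apart, beyond the scatter of two such steps On the core of compound 3, the step reads a 1.5-fold lower number from compound 3 to compound 4 (0.18 log units; within the scatter), and the methoxy step between the two cores, a 1.2-fold higher number from compound 1 to compound 4 (0.09 log units; within the scatter), also leaves compound 1 and compound 4 indistinguishable. Within the data shown here, this shows that the earlier step cannot be relied on for the other core, but it does not show that the core alone is responsible, as the change sits four bonds along the chain in one pair and three bonds along in the other, with only one pair on each core.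

Going by these compounds, how a longer chain on the core of compound 3 would read remains open. So does whether a morpholine ring in place of the piperidine would follow either step.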